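Acetyl on the Aromatic Ring: What to Expect for Compound 4

The source may hold more compounds than are shown below. What is called first, only, known or untested is meant among the compounds shown, and "the series" means these compounds.

Measured compounds:
Compound 1 `c1ccc(CN2CCC3(CC2)OCCc2c3csc2-c2ccccc2)cc1`, which in an assay on membranes from brain for displacement of a labelled ligand from Sigma non-opioid intracellular receptor 1 (Cavia porcellus), read by scintillation counting, with a stated time of 120 min (a higher number here means a weaker inhibitor, a lower number a stronger inhibitor), gives 4.5 nM for compound 1.
Compound 2 `N#Cc1ccc(-c2scc3c2CCOC32CCN(Cc3ccccc3)CC2)cc1`, which in this assay gives 3.4 nM for compound 2.
Compound 3 `COC1Cc2c(csc2-c2ccccc2)C2(CCN(Cc3ccccc3)CC2)O1`, which in this assay gives 1 nM for compound 3.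

Compound 3 stands at the lowest number of the three, and its distance from both compound 1 and compound 2 lies beyond the usual scatter. The step that brought it there is a 4.5-fold lower number from compound 1 to compound 3 (0.65 log units; beyond the scatter), a change on the saturated ring rather than on the aromatic ring.

Compound 4 `COC1Cc2c(csc2-c2ccc(C(C)=O)cc2)C2(CCN(Cc3ccccc3)CC2)O1` differs from compound 3 in one place: acetyl in place of hydrogen on an aromatic carbon.

For the measured compounds named here, the only measured step that bears on this change is a 1.3-fold lower number from compound 1 to compound 2 (0.12 log units; within the scatter), where a small group also entered on that same aromatic ring and the number barely moved. On that basis the change from compound 3 to compound 4 is expected to stay within the scatter; the expected step is a 1.2-fold higher number from compound 3 to compound 4 (0.08 log units; within the scatter), with no clear direction.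

For compound 4 in this assay the estimate is 1.2 nM, with a range from 0.5 nM to 3 nM.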

Compound 4, inhibition constant: 1.6 nM
The estimate for compound 4 lay 1.3-fold (0.12 log units) below the measured number; measured number inside the range.
By their numbers in this assay, from the lowest: compounds 3 and 4 (each within the scatter of the next); then compounds 2 and 1 (each within the scatter of the next).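

In this assay, the change from phenyl to 4-acetylphenyl gives a 1.6-fold higher number from compound 3 to compound 4 (0.20 log units; within the scatter), so this place on the aromatic ring accepts acetyl, a group of 3 heavy atoms with a carbonyl, while the number stays within the usual scatter. The earlier compounds shown here showed this only for cyano, and only in compound 2, which has no methoxy group on the saturated ring; compound 4 shows it in a compound that carries the methoxy group. Nothing shown here gives a reason for this result.

The compounds shown leave open whether a carboxylic acid, an amine or a longer chain at this place would also keep the number within the scatter. They also leave open whether acetyl would behave the same way on compound 1 , which lacks the methoxy group.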